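This account rests on a few compounds, and the source may have more. Where it says the series, first, only, none or still open, it means among the compounds named here.

Compound 1, `COc1cc(NC(C)CCCNC(=O)NNC(=O)Nc2ccc(Br)cc2)c2ncccc2c1`, measured in a functional assay on SW-620 cells (Homo sapiens) for inhibition, read by MTT assay, with a stated time of 72 h; a higher number here means a weaker inhibitor, a lower number a stronger inhibitor: compound 1 gives 17000 nM.
Compound 2, `COc1cc(NC(C)CCCNC(=O)NNC(=O)Nc2ccc(O)cc2)c2ncccc2c1`: compound 2 gives only a limit of this assay, > 100000 nM.
Compound 3, `COc1cc(NC(C)CCCNC(=O)NNC(=O)Nc2ccc(F)cc2)c2ncccc2c1`: compound 3 likewise gives only a limit, > 100000 nM.

Compound 3 therefore stands at the edge of what this assay can report, and it does not stand there alone, since (the limit of > 100000 nM in this assay, at which 2 of the 3 values shown sit). Within the data shown here, the only number among the three belongs to compound 1, from which both other compounds depart: an at least 5.8-fold higher number from compound 1 to compound 2 (0.76 log units; beyond the scatter), and an at least 5.8-fold higher number from compound 1 to compound 3 (0.76 log units; beyond the scatter). Between compound 2 and compound 3 the two limits leave a step that the two limits leave unreadable from compound 2 to compound 3.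

Compound 4, `COc1cc(NC(C)CCCNC(=O)NNC(=O)Nc2ccc(Cl)cc2)c2ncccc2c1`, differs from compound 3 in one place: chloro in place of fluoro on an aromatic carbon. Among the measured compounds shown here, no measured step covers this exact exchange. For the measured compounds named here, the steps that bear on it are those leaving the bromo compound, compound 1, which show that fluoro and hydroxy both drop the value past the limit, while bromo itself stays readable. Chloro sits between fluoro and bromo in this small series, so compound 4 is expected to return toward a readable number, an expected step of an at least 2.5-fold lower number from compound 3 to compound 4 (0.39 log units; beyond the scatter). The estimate for compound 4 is 40000 nM, with a range from 12000 nM to 130000 nM.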

Compound 4, half-maximal inhibitory concentration: 48000 nM
The estimate for compound 4 lay 1.2-fold (0.08 log units) below the measured number; the measured number falls inside the stated range.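

In this assay, the para position of this ring now gives a readable number with a halogen other than bromo, and the change to chloro moves the series off the limit: an at least 2.0-fold lower number from compound 3 to compound 4 (0.31 log units; beyond the scatter), and likewise an at least 2.0-fold lower number from compound 2 to compound 4 (0.31 log units; beyond the scatter). Chloro does not match bromo, however, and the gap between the two readable compounds is itself beyond the scatter: a 2.8-fold higher number from compound 1 to compound 4 (0.45 log units; beyond the scatter). The three halogens shown thus fall in the order fluoro, chloro, bromo, with the lowest number on bromo, a pattern that rests on compound 1, compound 3 and compound 4 alone, while the hydroxy of compound 2 stands outside it and the step between compound 2 and compound 3 still cannot be read, and compound 2 and compound 3 remain limits rather than numbers: the limit of > 100000 nM in this assay, at which 2 of the 4 values shown sit.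

The compounds shown leave open whether iodo at the same place would carry this order past bromo, and whether a methyl, a methoxy or an amine there would return a readable number. They also leave open whether a longer chain in the shared core would shift the values of compound 1 and compound 4 together.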